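Adding a Second Hydroxy Group: From Compound 2 to Compound 3

This account rests on a few compounds, and the source may have more. Where it says the series, first, only, none or still open, it means among the compounds named here.

Measured in a functional assay, tested at 10 uM (a lower number here means a weaker effect, a higher number a stronger effect of the compound at the concentration tested), so far:
- Compound 1 `O=C(Cn1c(=O)c(/C=C/c2ccccc2)nc2ccccc21)NS(=O)(=O)C(F)(F)F` gives 6.4%
- Compound 2 `O=C(Cn1c(=O)c(/C=C/c2ccc(O)cc2)nc2ccccc21)NS(=O)(=O)C(F)(F)F` gives 13.2%

For the measured compounds named here, compound 2 and compound 1 share the same core and give numbers that sit within the scatter of one another; the single measured step, a number 6.8 percentage points higher from compound 1 to compound 2 (within the scatter), is the only comparison available, and it does not separate the two compounds.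

Compound 3 `O=C(Cn1c(=O)c(/C=C/c2ccc(O)c(O)c2)nc2ccccc21)NS(=O)(=O)C(F)(F)F` differs from compound 2 by hydroxy in place of hydrogen on an aromatic carbon. Going by the values given here, the one step that bears on this change is hydroxy in place of hydrogen on an aromatic carbon, a number 6.8 percentage points higher from compound 1 to compound 2 (within the scatter), which stayed within the scatter. A second hydroxy group is therefore expected to move the number little in this assay, if at all, with at most a slight rise. Compound 3 is estimated at 18%, between 6% and 35%, an expected step of a number 4.8 percentage points higher from compound 2 to compound 3 (within the scatter).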

Compound 3, a percentage reported as activity, at one concentration (the size of the read-out at that concentration, not a potency): 82.1%
Compound 3: middle estimate off by 64.1 percentage points, on the low side, outside the stated range (above it).
By their numbers in this assay, from the lowest: compounds 1 and 2 (each within the scatter of the next); then compound 3.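

In this assay, a hydroxy group placed ortho to a hydroxy group on the aromatic ring turns out to be a large change (a number 68.9 percentage points higher from compound 2 to compound 3 (beyond the scatter)), although the same kind of swap on the unsubstituted ring did not separate two compounds (a number 6.8 percentage points higher from compound 1 to compound 2 (within the scatter)). Taken whole, 3,4-dihydroxyphenyl in place of phenyl gives a large step too (a number 75.7 percentage points higher from compound 1 to compound 3 (beyond the scatter)), so in these three compounds the outcome of adding a hydroxy group depends on what already sits on the ring. Nothing measured here explains the jump.

Still open, on these data alone, is whether a methoxy group, an amine or a fluorine in place of the new hydroxy group would keep the number this high. Also open, as far as these compounds go, is whether the new hydroxy group could give such a step without the hydroxy group ortho to it.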